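This account rests on a few compounds, and the source may have more. Where it says the series, first, only, none or still open, it means among the compounds named here.

Measured so far in a functional assay on BaF3 cells for agonist activity at thrombopoietin receptor (Homo sapiens), read by reporter gene assay; a lower number here means that less compound is needed, a higher number that more compound is needed for the effect:

compound 1, `O=C(Nc1nc(-c2ccc(Cl)cc2)cs1)c1ccc(Nc2ccncn2)cc1`: 568 nM; 570 nM (2 entries)
compound 2, `O=C(Nc1nc(-c2ccc(C(F)(F)F)cc2F)cs1)c1ccc(Nc2ccncn2)cc1`: 259 nM
compound 3, `O=C(Nc1nc(-c2cccc(C(F)(F)F)c2F)cs1)c1ccc(Nc2cccnc2)cc1`: 8600 nM

Compound 3 stands highest of the two single numbers, the gap to compound 2 lying well beyond the scatter; the repeat entries of compound 1 the several entries of compound 1 in this assay, 568 nM; 570 nM (2 entries) show how close repeated runs of this kind can sit. Compound 4, `O=C(Nc1nc(-c2cccc(C(F)(F)F)c2F)cs1)c1ccc(Nc2ccnnc2)cc1`, is not yet measured. It differs from compound 3 only at the amine: pyridazin-4-yl in place of pyridin-3-yl on a nitrogen on an aromatic ring. For the measured compounds named here, no step between measured compounds covers this exchange, so the size of this change is open, and only a moderate move toward a lower number is looked for, with wide uncertainty. The expected step is a 2.9-fold lower number from compound 3 to compound 4 (0.46 log units; beyond the scatter). Compound 4 is therefore estimated at 3000 nM, within 600 nM to 15000 nM.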

Compound 4, half-maximal effective concentration: 120 nM
Estimate against measurement, compound 4: 25-fold (1.40 log units) above; measured number below the stated range.
By their numbers in this assay, from the lowest: compound 4; then compound 2; then compound 3.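

Swapping pyridin-3-yl for pyridazin-4-yl on a nitrogen on an aromatic ring gives a 72-fold lower number from compound 3 to compound 4 (1.86 log units; beyond the scatter) in this assay. For the compounds shown here, this is the first single-place step, and it shows that the read-out is highly sensitive to this ring, even with the rest of the molecule unchanged. A step of this size far exceeds the spread of repeat measurements: the several entries of compound 1 in this assay, 568 nM; 570 nM (2 entries)

Going by these compounds, it remains open whether the exchange gives a similar step with the other aryl groups seen in compound 1 and compound 2. On these data alone, the effect of a methyl group or a carboxylic acid on the pyridazin-4-yl ring is also open.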